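The source may hold more compounds than are shown below. What is called first, only, known or untested is meant among the compounds shown, and "the series" means these compounds.

Compound 1 `COc1cc(-c2cc(/C=C/C(=O)c3ccc(N)cc3)[nH]n2)cc(OC)c1OC`: in a functional assay on OVCAR-3 cells (Homo sapiens) for inhibition, read by sulforhodamine B assay, with a stated time of 48 h (on this read-out lower numbers stand for stronger inhibition of growth and higher numbers for weaker inhibition of growth), compound 1 gives 3370 nM
Compound 2 `COc1ccc(-c2cc(/C=C/C(=O)c3cc(OC)c(OC)c(OC)c3)[nH]n2)cc1OC`: in this assay compound 2 gives 3150 nM

Compound 1 stands as the higher of the two numbers, but its gap to compound 2 lies within the scatter, so the two cannot be set apart. Compound 3 `COc1cc(-c2cc(/C=C/C(=O)c3ccc(F)c(F)c3)[nH]n2)cc(OC)c1OC` differs from compound 1 in one place: 3,4-difluorophenyl in place of 4-aminophenyl on a carbonyl carbon. Within the data shown here, no measured pair shows this change, so the account rests on compound 1 alone. Compound 3 is therefore expected to stay near compound 1, with no step beyond the scatter. Compound 3 is estimated at 3500 nM, between 1200 nM and 10000 nM, which means the step of a 1.0-fold higher number from compound 1 to compound 3 (0.02 log units; within the scatter) is expected.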

Compound 3, concentration for total growth inhibition: 6250 nM
For compound 3 the middle estimate is 1.8-fold (0.25 log units) below the measured one; low and high end bracket the measured number.
By their numbers in this assay, from the lowest: compounds 2, 1 and 3 (each within the scatter of the next).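

In this assay, 3,4-difluorophenyl in place of 4-aminophenyl on a carbonyl carbon gives a 1.9-fold higher number from compound 1 to compound 3 (0.27 log units; within the scatter). This first reading at this position shows that losing the hydrogen-bond donor and acceptor counted on 4-aminophenyl goes with no step beyond the scatter. No measurement is at hand that could account for this result. The compounds shown leave open whether a plain phenyl, or a phenyl carrying a carboxylic acid, on that carbonyl carbon would move the number beyond the scatter.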